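The source may hold more compounds than are shown below. What is called first, only, known or untested is meant among the compounds shown, and "the series" means these compounds.

Measured so far in a functional assay on HL-60 cells (Homo sapiens) for cytotoxicity, read by MTT assay; a higher number here means a weaker inhibitor, a lower number a stronger inhibitor:

compound 1 `O=C(N/N=C/c1ccc(F)cc1)c1cn(C2CC2)c2cc(N3CCNCC3)c(F)cc2c1=O` gives 25000 nM
compound 2 `O=C(N/N=C/c1ccccc1)c1cn(C2CC2)c2cc(N3CCNCC3)c(F)cc2c1=O` gives 25000 nM

For the measured compounds named here, compound 2 stands level with compound 1, the only neighbour measured so far. Compound 3 `COc1ccc(/C=N/NC(=O)c2cn(C3CC3)c3cc(N4CCNCC4)c(F)cc3c2=O)cc1O` differs from compound 2 in one place, with 3-hydroxy-4-methoxyphenyl in place of phenyl on a carbon with a double bond to nitrogen. Going by the values given here, one measured step bears on this change, and it concerns the same aromatic group: no change at the digits printed from compound 1 to compound 2 (within the scatter), with hydrogen in place of fluoro on an aromatic carbon. That step lies within the scatter, but it is a small exchange and offers only a weak guide. Among the compounds with values here, no measured compound carries a hydroxy or a methoxy group, so the data do not show what the larger group does in this assay. On this evidence, no step beyond the scatter is expected, though the uncertainty is wide in both directions. The expected step is a 1.3-fold lower number from compound 2 to compound 3 (0.10 log units; within the scatter). For compound 3 the estimated value is 20000 nM, with an expected range from 6000 nM to 45000 nM.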

Compound 3, half-maximal inhibitory concentration: 25000 nM
The estimate for compound 3 lay 1.3-fold (0.10 log units) below the measured number; low and high end bracket the measured number.
By their numbers in this assay, from the lowest: compounds 1, 2 and 3 (each within the scatter of the next).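

In this assay, putting 3-hydroxy-4-methoxyphenyl in place of phenyl on a carbon with a double bond to nitrogen gives no change at the digits printed from compound 2 to compound 3 (within the scatter) and putting it in place of 4-fluorophenyl gives no change at the digits printed from compound 1 to compound 3 (within the scatter) on the same carbon. The earlier pair had tested only hydrogen in place of fluoro on an aromatic carbon, whereas this exchange brings in a group of 9 heavy atoms with 1 hydrogen-bond donor and 2 hydrogen-bond acceptors, and the three compounds still print the same number, so a far larger exchange at this position also leaves the reading within the scatter. Nothing else measured here accounts for this result.

The compounds shown leave open whether the hydroxy and the methoxy group would each behave the same alone, since they enter together in compound 3. They also leave open whether an amine or a carboxylic acid on this aromatic ring, a longer chain in place of the ring, or any change elsewhere on the shared core would shift the number in this assay at all.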